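The source may report more compounds than this note shows. Statements on the series, on what has been measured and on what is new or still open speak of the compounds shown alone.

In a functional assay on HepG2 cells (Homo sapiens) for antiproliferative activity, read by MTT assay, with a stated time of 24 h (a higher number here means a weaker inhibitor, a lower number a stronger inhibitor), compound 1 `COc1cc(OC)c(-c2coc3cc(OCC=C(C)C)ccc3c2=O)cc1OC` gives 280 nM and compound 2 `COc1cc(OC)c(-c2coc3cc(OCc4ccc(Cl)cc4)ccc3c2=O)cc1OC` gives 940 nM, the higher of the two numbers and so the weaker result. Compound 3 `COc1cc(OC)c(-c2coc3cc(OCc4cccc(Cl)c4)ccc3c2=O)cc1OC` is still unmeasured. It differs from compound 2 by one change: 3-chlorophenyl in place of 4-chlorophenyl on a saturated chain carbon bound to an oxygen on an aromatic ring. Among the measured compounds shown here, the only measured step, a 3.4-fold higher number from compound 1 to compound 2 (0.53 log units; beyond the scatter), came from replacing 2-methylprop-1-en-1-yl with 4-chlorophenyl, so it bears only loosely on a change that rejoins the same atoms. With no measured comparison of 3-chlorophenyl and 4-chlorophenyl, no shift beyond the scatter is expected in this assay. The expected change is a 1.1-fold lower number from compound 2 to compound 3 (0.04 log units; within the scatter). For compound 3, the estimate is 850 nM, with an expected range of 350 nM to 2100 nM.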

Compound 3, half-maximal inhibitory concentration: 750 nM
For compound 3 the middle estimate is 1.1-fold (0.05 log units) above the measured one; the measured number falls inside the stated range.
By their numbers in this assay, from the lowest: compound 1; then compounds 3 and 2 (each within the scatter of the next).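

In this assay, exchanging 4-chlorobenzyl for 3-chlorobenzyl on the oxygen gives a 1.3-fold lower number from compound 2 to compound 3 (0.10 log units; within the scatter), so this change of chlorine placement makes no clear difference in this pair. Replacing the 2-methylprop-1-en-1-yl group of compound 1 with 3-chlorophenyl gives a 2.7-fold higher number from compound 1 to compound 3 (0.43 log units; beyond the scatter), showing that the weaker result seen with 4-chlorophenyl also appears with a second chlorophenyl group. No available measurement explains either step. The compounds shown leave open how an unsubstituted benzyl group or a longer chain would compare on the same oxygen.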